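The compounds below may be only part of what the source reports. "The series", "measured", "known", "first", "only" and "open" are said of these compounds alone.

The account starts from compound 2 `Cc1ccc(CNc2ncnc3c2ncn3[C@@H]2O[C@H](CO)[C@@H](O)[C@H]2O)cc1`. In a functional assay on CCRF-CEM cells (Homo sapiens) for antiproliferative activity, with a stated time of 72 h (a higher number here means a weaker inhibitor, a lower number a stronger inhibitor), compound 2 gives > 166000 nM, which is a limit of the assay rather than a number. Compound 2 thus sits at the limit of > 166000 nM in this assay, at which 1 of the 2 values shown sits, the weaker end of the two values recorded so far. Compound 3 `OC[C@H]1O[C@@H](n2cnc3c(NCc4c(F)ccc(F)c4F)ncnc32)[C@H](O)[C@@H]1O` differs from compound 2 in one place: 2,3,6-trifluorophenyl in place of 4-methylphenyl on a saturated chain carbon bound to a nitrogen on an aromatic ring. Among the compounds with values here, the only measured step that bears on this change runs the opposite way, from compound 1 `OC[C@H]1O[C@@H](n2cnc3c(NCc4ccccc4F)ncnc32)[C@H](O)[C@@H]1O`, which in this assay gives 4600 nM, to compound 2, and it reads an at least 36-fold higher number from compound 1 to compound 2 (1.55 log units; beyond the scatter). Because an at least 36-fold higher number from compound 1 to compound 2 (1.55 log units; beyond the scatter) accompanied the exchange of a fluorine-bearing ring for 4-methylphenyl, the return to a fluorine-bearing ring in compound 3 is expected to reverse much of that loss, and a step of an at least 33-fold lower number from compound 2 to compound 3 (1.52 log units; beyond the scatter) is expected in this assay. Compound 3 is therefore estimated at 5000 nM, with a range from 1200 nM to 40000 nM.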

Compound 3, half-maximal inhibitory concentration: 90300 nM
Compound 3: middle estimate off by 18-fold (1.26 log units), on the low side; measured number above the stated range.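

Set against 2-fluorophenyl, 2,3,6-trifluorophenyl on this saturated chain carbon gives a 20-fold higher number from compound 1 to compound 3 (1.29 log units; beyond the scatter) in this assay, so a fluorine-bearing ring at this place does not by itself keep the activity of compound 1, which stays the strongest of the three. Compound 2 stands at a limit of the assay, not a number: the limit of > 166000 nM in this assay, at which 1 of the 3 values shown sits. Against that limit the reading is only an at least 1.8-fold lower number from compound 2 to compound 3 (0.26 log units; that floor lies within the scatter), so the compounds do not establish that 2,3,6-trifluorophenyl and 4-methylphenyl differ at all.

The compounds shown leave open which of the added fluorines goes with the loss seen from compound 1. Also open, going by these compounds, is how an unsubstituted phenyl ring, or a phenyl ring bearing a chlorine or a methoxy group, would read in this assay.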